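A few compounds are considered here, and "the series" means these few. Any claim that something is new, unique, unknown or untested is made for them only; others in the source may bear on it.

Compound 2 `COc1c(C)cnc(CNc2ccc3c(c2)nc(C)n3C[C@@H](O)[C@H]2O[C@H](O)[C@@H](O)[C@H]2O)c1C` gives 56% in a functional assay on the whole organism (strain Sprague-Dawley) for inhibition, with Rattus norvegicus as the target, read by paw edema, with a stated time of 180 min, at a dose of 30 mg/kg by the oral route (on this read-out lower numbers stand for a weaker effect and higher numbers for a stronger effect at the one dose given), the second highest of the three numbers; compound 1 `COc1ccnc(CNc2ccc3c(c2)nc(C)n3C[C@@H](O)[C@H]2O[C@H](O)[C@@H](O)[C@H]2O)c1C` gives 58% and compound 3 `Cc1nc2cc(NCc3ccccn3)ccc2[nH]1` gives 45%. Going by the values given here, the step of a number 2 percentage points lower from compound 1 to compound 2 (within the scatter) is the only single-point step measured. Compound 4 `Cc1nc2cc(NCc3ccccn3)ccc2n1C[C@@H](O)[C@H]1O[C@H](O)[C@@H](O)[C@H]1O` differs from compound 2 by pyridin-2-yl in place of 4-methoxy-3,5-dimethylpyridin-2-yl on a saturated chain carbon bound to a nitrogen on an aromatic ring. Among the compounds with values here, no measured step removes the methoxy and both methyls together; the one bearing step, a number 2 percentage points lower from compound 1 to compound 2 (within the scatter), stays within the scatter, while compound 3 carries the same pyridin-2-yl and reads lower than compound 2. A small downward step is therefore expected, a number 6 percentage points lower from compound 2 to compound 4 (within the scatter), close to the scatter. Compound 4 is estimated at 50%, between 38% and 62%.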

Compound 4, a percentage reported as inhibition, in the whole organism at one dose (the size of the read-out at that dose, not a potency): 52%
Estimate against measurement, compound 4: 2 percentage points below; the measured number falls inside the stated range.
By their numbers in this assay, from the lowest: compounds 3, 4, 2 and 1 (each within the scatter of the next, the first and the last beyond it).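

Across this assay, the full change on a saturated chain carbon bound to a nitrogen on an aromatic ring reads a number 4 percentage points lower from compound 2 to compound 4 (within the scatter) and likewise a number 6 percentage points lower from compound 1 to compound 4 (within the scatter). The methoxy and methyl groups together therefore do not separate from the bare pyridin-2-yl at this single dose, which extends the earlier methyl-only comparison to the whole substitution pattern. Nothing on hand explains this flat result.

Open, from the compounds shown here alone, is whether a phenyl ring or a pyridin-2-yl bearing a carboxylic acid would move the read-out beyond the scatter. Also open, going by these compounds, is whether these groups would separate at other doses.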